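The source may report more compounds than this note shows. Statements on the series, on what has been measured and on what is new or still open speak of the compounds shown alone.

Compound 1 `N#Cc1ccc(CN([C@H](CCC(F)(F)F)C(N)=O)S(=O)(=O)c2ccc(Cl)cc2)cc1`: 19.7 10^-6 cm/s
Compound 2 `N#CCCCN([C@H](CCC(F)(F)F)C(N)=O)S(=O)(=O)c1ccc(Cl)cc1`: 27.6 10^-6 cm/s

Going by the values given here, both numbers come from an ADME assay on MDCKII-LE cells (Canis lupus familiaris) for permeability (on this read-out higher numbers stand for higher permeability and lower numbers for lower permeability), and compound 1 holds the lower of the two; the only measured step, a 1.4-fold higher number from compound 1 to compound 2 (0.15 log units; within the scatter), lies within the scatter. Compound 3 `N#C[C@H]1C[C@@H](CN([C@H](CCC(F)(F)F)C(N)=O)S(=O)(=O)c2ccc(Cl)cc2)C1` has not been measured. It differs from compound 1 in one place: 3-cyanocyclobutyl in place of 4-cyanophenyl on a saturated chain carbon bound to a sulfonamide nitrogen. The step from compound 1 to compound 2 bears on this, since it too removes the 4-cyanophenyl from the saturated chain carbon bound to a sulfonamide nitrogen and puts a nitrile-bearing group in its place, and it produced no change beyond the scatter. A step of no more than the scatter in this assay is therefore expected. Compound 3 is estimated at 22 10^-6 cm/s, between 12 10^-6 cm/s and 40 10^-6 cm/s. The expected step is a 1.1-fold higher number from compound 1 to compound 3 (0.05 log units; within the scatter).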

Compound 3, apparent permeability: 24.1 10^-6 cm/s
Estimate against measurement, compound 3: 1.1-fold (0.04 log units) below; the measured number falls inside the stated range.
By their numbers in this assay, from the lowest: compounds 1, 3 and 2 (each within the scatter of the next).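

In this assay, the 3-cyanocyclobutyl in place of 4-cyanophenyl gives a 1.2-fold higher number from compound 1 to compound 3 (0.09 log units; within the scatter), and in place of 2-cyanoethyl it gives a 1.1-fold lower number from compound 2 to compound 3 (0.06 log units; within the scatter). On this saturated chain carbon bound to a sulfonamide nitrogen, an aromatic ring, a four-membered non-aromatic ring and an open chain therefore all read alike, each within the scatter of the others. No measurement at hand offers a reason for this sameness. On these data alone, all three compounds still carry a nitrile, so the read-out with a group lacking it, such as an amine or a carboxylic acid, remains open.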